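This account rests on a few compounds, and the source may have more. Where it says the series, first, only, none or still open, it means among the compounds named here.

In an assay on isolated protein for inhibition of histone deacetylase 5 (Homo sapiens), tested at 1 uM (on this read-out lower numbers stand for less inhibition and higher numbers for more inhibition at the one concentration tested (going by the name of the read-out)), compound 1 `CC(C)[C@@H](C(=O)Nc1ccc(C(=O)Nc2ccccc2N)cc1)c1ccccc1` gives 9%, compound 2 `CC(C)[C@@H](C(=O)Nc1ccc(C(=O)Nc2ccc(F)cc2N)cc1)c1ccccc1` gives 0%, and compound 3 `CC(C)[C@H](C(=O)Nc1ccc(C(=O)Nc2ccccc2N)cc1)c1ccccc1` gives 0%. Compound 2 stands level with compound 3, the two together the lowest of the three, and its nearest neighbour is compound 3 with no change at the digits shown, while compound 1 is the furthest, a number higher that stays within the scatter. The two measured steps are a number 9 percentage points lower from compound 1 to compound 2 (within the scatter) and a number 9 percentage points lower from compound 1 to compound 3 (within the scatter), the latter a change in configuration only (the fact that compounds 1 and 3 differ only in the configuration as drawn). Compound 4 `Nc1cc(F)ccc1NC(=O)c1ccc(NC(=O)C2CC2c2ccccc2)cc1` is reached from compound 2 by 2-phenylcyclopropyl in place of 2-methyl-1-phenylpropyl on a carbonyl carbon. Neither measured step touches this part of the molecule, and both lie within the scatter, so no step beyond the scatter is expected in this assay, estimated as a number 3 percentage points higher from compound 2 to compound 4 (within the scatter). Compound 4 is expected to give about 3% in this assay, between -8% and 15%.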

Compound 4, a percentage reported as inhibition, at one concentration (the size of the read-out at that concentration, not a potency): 3%
The estimate for compound 4 equals the measured number at the digits printed; measured number inside the range.
By their numbers in this assay, from the lowest: compounds 2, 3, 4 and 1 (each within the scatter of the next).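

In this assay, 2-phenylcyclopropyl in place of 2-methyl-1-phenylpropyl on a carbonyl carbon gives a number 3 percentage points higher from compound 2 to compound 4 (within the scatter), so a three-membered non-aromatic ring can enter this position without a step beyond the scatter. Compound 4 also has no defined stereocentre, and this change too leaves the number within the scatter. Nothing measured here explains this result.

Going by these compounds, whether an amine or a carboxylic acid on this carbonyl carbon would give a step beyond the scatter remains open. So does whether any change here would matter, since all steps so far lie within the scatter.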